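Swapping fluoro for chloro: an expected lipophilicity step

A few compounds are considered here, and "the series" means these few. Any claim that something is new, unique, unknown or untested is made for them only; others in the source may bear on it.

Measured compounds:
compound 1 `COc1ccc(NC(=O)c2ccc3cccc(O)c3n2)cc1`: 2.5
compound 2 `O=C(Nc1ccc(F)cc1)c1ccc2cccc(O)c2n1`: 2.5

In a physicochemical assay for lipophilicity, read by HPLC (a higher number here means a more lipophilic compound, a lower number a more polar compound), compound 2 stands level with compound 1, within the scatter. Compound 3 `O=C(Nc1ccc(Cl)cc1)c1ccc2cccc(O)c2n1` carries the change (chloro in place of fluoro on an aromatic carbon), on an aromatic carbon of a six-membered aromatic ring of carbon only. For the measured compounds named here, the one measured step, no change at the digits printed from compound 1 to compound 2 (within the scatter), concerns a different swap at the same place and does not settle this one. Chloro is a heavier halogen than fluoro, so a small rise in this assay is expected here, about a number 0.40 log units higher from compound 2 to compound 3 (beyond the scatter). For compound 3 the expected value is 2.9, between 2.6 and 3.3.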

Compound 3, partition coefficient: 2.5
Estimate against measurement, compound 3: 0.40 log units above; measured number below the stated range.
By their numbers in this assay, from the lowest: compounds 1, 2 and 3 (each within the scatter of the next).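

In this assay, chloro in place of fluoro on this aromatic carbon gives no change at the digits printed from compound 2 to compound 3 (within the scatter), and chloro in place of methoxy gives no change at the digits printed from compound 1 to compound 3 (within the scatter). For the compounds shown here, three different groups at this one place, para to a large group, now read level, where the earlier compounds offered only two. Nothing measured here explains why chloro reads level with fluoro. On these data alone, whether that level reading holds for an amine, a carboxylic acid or a longer chain at this place stays open. So does whether it would persist with a change to the shared core.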